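Butyl in place of difluoromethoxy on a shared sulfonamide core

A few compounds are considered here, and "the series" means these few. Any claim that something is new, unique, unknown or untested is made for them only; others in the source may bear on it.

Compound 1 `O=C1NCCN1c1ccc(S(=O)(=O)Nc2ccc(OC(F)F)cc2)cc1` is tested in a functional assay on HT-29 cells (Homo sapiens) for antiproliferative activity, read by sulforhodamine B assay, with a stated time of 48 h (on this read-out lower numbers stand for stronger inhibition and higher numbers for weaker inhibition), where compound 1 gives 650 nM. On this read-out compound 1 stands at the highest of the three numbers: compound 2 `Cc1cc(C)cc(NS(=O)(=O)c2ccc(N3CCNC3=O)cc2)c1` gives 82 nM, and compound 3 `COc1cc(NS(=O)(=O)c2ccc(N3CCNC3=O)cc2)cc(OC)c1` gives 78 nM, both beyond the usual scatter from compound 1. Compound 4 `CCCCc1ccc(NS(=O)(=O)c2ccc(N3CCNC3=O)cc2)cc1` has not yet been measured in this assay. It differs from compound 1 in one place (butyl in place of difluoromethoxy on an aromatic carbon). Going by the values given here, no directly comparable pair has been measured, so the step is open. A moderate move toward a lower number is expected, a 3.0-fold lower number from compound 1 to compound 4 (0.47 log units; beyond the scatter), because compound 2 gives 82 nM with a carbon-only substituent pattern. Compound 4 is therefore estimated at 220 nM, within 60 nM to 800 nM.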

Compound 4, half-maximal inhibitory concentration: 610 nM
Compound 4: the middle estimate sits 2.8-fold (0.44 log units) below what was measured; measured number inside the range.
By their numbers in this assay, from the lowest: compounds 3 and 2 (each within the scatter of the next); then compounds 4 and 1 (each within the scatter of the next).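

Placing butyl in the spot held by difluoromethoxy, on an aromatic carbon para to a large group, gives a 1.1-fold lower number from compound 1 to compound 4 (0.03 log units; within the scatter), so the two compounds cannot be told apart in this assay. At this position, an all-carbon chain and an oxygen- and fluorine-bearing group of equal heavy-atom count therefore read alike, even though only difluoromethoxy counts a hydrogen-bond acceptor. No measurement available here accounts for this match.

As far as these compounds go, whether an amine or a carboxylic acid at this position would separate from these two values remains open.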